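A few compounds are considered here, and "the series" means these few. Any claim that something is new, unique, unknown or untested is made for them only; others in the source may bear on it.

Compound 1, `CCc1cc(C(C)=O)c(O)cc1OCCCCC#N`, in an assay on isolated protein for binding affinity to leukotriene B4 receptor 1 (Homo sapiens), tested at 1 uM (on this read-out higher numbers stand for more inhibition at the one concentration tested (going by the name of the read-out) and lower numbers for less inhibition), gives 57%.
Compound 2, `CCc1cc(C(C)=O)c(O)cc1OCCCCCC(C)(C)C#N`, gives 53%.
Compound 3, `CCc1cc(C(C)=O)c(O)cc1OCCCC(C)(C)C(N)=O`, gives 51%.

All three compounds share the same core and differ only at the far end of the chain attached to the aromatic oxygen. On the numbers, compound 3 has the lowest value of the three, but its distance to compound 2 and to compound 1 lies within the scatter, so no order among them can be claimed.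

Compound 4, `CCc1cc(C(C)=O)c(O)cc1OCCCC(C)(C)c1nnn[nH]1`, has not been measured. It differs from compound 3 in one place:
1H-tetrazol-5-yl in place of carbamoyl on a saturated chain carbon bound to three saturated chain carbons

The measured steps all stay at the chain end: a number 4 percentage points lower from compound 1 to compound 2 (within the scatter), a number 6 percentage points lower from compound 1 to compound 3 (within the scatter), and a number 2 percentage points lower from compound 2 to compound 3 (within the scatter). Each of them is within the scatter, whether the end group is a nitrile or a carbamoyl and whatever the branching. Among the measured compounds shown here, none of these steps involves a 1H-tetrazol-5-yl, so there is no direct precedent for compound 4. Given that every change so far at this position left the read-out essentially unmoved, the expectation is that compound 4 also shows no step beyond the scatter, a number 1 percentage points higher from compound 3 to compound 4 (within the scatter). Compound 4 is therefore estimated at 52%, with a range from 35% to 70%.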

Compound 4, a percentage reported as inhibition, at one concentration (the size of the read-out at that concentration, not a potency): 76%
Compound 4: the middle estimate sits 24 percentage points below what was measured; measured number outside the range, above it.
By their numbers in this assay, from the lowest: compounds 3, 2 and 1 (each within the scatter of the next); then compound 4.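

In this assay, among the compounds shown here, the end of this chain turns out to matter: 1H-tetrazol-5-yl in place of carbamoyl on the saturated chain carbon gives a number 25 percentage points higher from compound 3 to compound 4 (beyond the scatter) and is the first change here to clear the usual scatter. Set against the two nitrile-ended chains, the new end group gives a number 23 percentage points higher from compound 2 to compound 4 (beyond the scatter) and a number 19 percentage points higher from compound 1 to compound 4 (beyond the scatter) so it stands apart from all three earlier end groups, which cannot be ordered among themselves. The swap replaces an open carbamoyl with a five-membered aromatic ring with 4 hetero atoms, but nothing presented here says why the number rises.

A carboxylic acid on the same saturated chain carbon, or another five-membered aromatic ring there, would help show whether the rise belongs to 1H-tetrazol-5-yl alone or is shared by other end groups. It also remains open whether 1H-tetrazol-5-yl holds its number on a longer chain or without the two methyl groups of 1-(1H-tetrazol-5-yl)-1-methylethyl, and a reading at one concentration gives no potency for any of these compounds.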